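Replacing a methyl ester with a pyridinylmethyl amide

This account rests on a few compounds, and the source may have more. Where it says the series, first, only, none or still open, it means among the compounds named here.

Compound 1 `COC(=O)c1ccc2ccc(C(=O)c3ccccc3)c-2cc1` carries a methyl ester on its core. In a physicochemical assay for lipophilicity, read by HPLC, measured as octanol-water partition, at pH 2 (a lower number here means a more polar compound, a higher number a more lipophilic compound), compound 1 gives 4.8. Going by the values given here, the only other measured compound is compound 2 `COC(=O)c1ccc2c(C(=O)c3ccccc3)cc(C(=O)c3ccccc3)c-2cc1`, which gives 5.6 in this assay; the step of a number 0.80 log units higher from compound 1 to compound 2 (beyond the scatter) comes from a benzoyl in place of hydrogen on an aromatic carbon. Compound 1 thus has the lower of the two numbers, with compound 2 the higher by a margin beyond the scatter.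

Compound 3 `O=C(NCc1cccnc1)c1ccc2ccc(C(=O)c3ccccc3)c-2cc1` differs from compound 1 at the ester: ((pyridin-3-yl)methyl)amino in place of methoxy on a carbonyl carbon. Among the compounds with values here, no measured step touches this part of the molecule, and the one known step concerns a different kind of change, so it gives little direct guidance. The change exchanges a small methoxy group for a larger group that brings one hydrogen-bond donor and a six-membered aromatic ring with one hetero atom. The expectation is that this assay moves downward, by an estimated a number 2.20 log units lower from compound 1 to compound 3 (beyond the scatter). Compound 3 is therefore estimated at 2.6, with a likely range from 1.6 to 3.6.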

Compound 3, distribution coefficient: 1.4
Compound 3: middle estimate off by 1.20 log units, on the high side, and the stated range ends above it.
By their numbers in this assay, from the lowest: compound 3; then compound 1; then compound 2.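

Going by these compounds alone, at the carbonyl carbon that carries the ester, ((pyridin-3-yl)methyl)amino in place of methoxy moves this assay strongly, with a number 3.40 log units lower from compound 1 to compound 3 (beyond the scatter), so this part of the molecule, which no earlier step touched, clearly matters for the read-out. Within the data shown here, the change also runs in the opposite direction to the only earlier step, a number 0.80 log units higher from compound 1 to compound 2 (beyond the scatter), and it is the large one of the two, where that earlier step is modest. The swap brings in a hydrogen-bond donor and a six-membered aromatic ring with 1 hetero atom together, and no supporting measurement is available to explain how far the number moved.

Still open, going by these compounds, is which part of the entering group carries the step: benzylamino on the same carbonyl carbon would keep the amide and the chain but lose the hetero atom of the ring, while methylamino would keep only the amide. Also open, on these data alone, is whether the same exchange would give a step of similar size on compound 2, which carries the same methyl ester.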